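The source may hold more compounds than are shown below. What is called first, only, known or untested is meant among the compounds shown, and "the series" means these compounds.

Three compounds have a measured half-life in an ADME assay on microsomes from liver (Mus musculus) for metabolic stability; a lower number here means that the compound disappears faster, a higher number that the compound lasts longer. Compound 1 `CCC(CC)(c1nnc[nH]1)c1ccc(-c2ccc3cc(F)cc(F)c3c2)[nH]c1=O` gives 1.09 h, and compound 2 `CC(C)C(c1ncco1)c1ccc(-c2ccc3cccc(F)c3c2)[nH]c1=O` gives 0.08 h. Compound 3 `CCn1ncc2c(F)cc(-c3ccc(C(CC)(CC)c4nncn4C)c(=O)[nH]3)cc21` gives > 3 h, which is a limit of the assay and not a number. Compound 2 therefore has the lower of the two actual numbers, and its gap to compound 1 lies beyond the usual scatter.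

The next compound to follow is compound 4 `Cc1nc(C(c2ccc(-c3ccc4cccc(F)c4c3)[nH]c2=O)C(C)C)[nH]c1C`, which has not yet been measured. Its difference from compound 2 lies in one place: 4,5-dimethyl-1H-imidazol-2-yl in place of 1,3-oxazol-2-yl on a saturated chain carbon bound to an aromatic carbon and a saturated chain carbon. In words, 4,5-dimethyl-1H-imidazol-2-yl stands in place of 1,3-oxazol-2-yl on a saturated chain carbon bound to an aromatic carbon and a saturated chain carbon.

Among the compounds with values here, no two measured compounds differ in only one place, so no measured step shows what a change like this does, and any forecast is uncertain. A small rise in this assay, perhaps no larger than the scatter, seems the most reasonable expectation, since compound 2 starts from only 0.08 h. The estimated step is a 1.5-fold higher number from compound 2 to compound 4 (0.18 log units; within the scatter). For compound 4, the expected half-life is 0.12 h, with an estimated range of 0.05 h to 0.4 h.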

Compound 4, half-life: 0.0817 h
Beside the measured number, compound 4's estimate is 1.5-fold (0.17 log units) above it; the range from low to high includes it.
By their numbers in this assay, from the lowest: compounds 2 and 4 (each within the scatter of the next); then compound 1. At a limit, above all of these: compound 3.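

Within the data shown here, this is the first pair of compounds that differ in one place, and it gives a direct reading of this position in this assay: with 4,5-dimethyl-1H-imidazol-2-yl in place of 1,3-oxazol-2-yl on a saturated chain carbon bound to an aromatic carbon and a saturated chain carbon, the step is a 1.0-fold higher number from compound 2 to compound 4 (0.01 log units; within the scatter). The change is not a trivial one on paper, since the entering group has 7 heavy atoms against 5, carries two ring nitrogens instead of a nitrogen and an oxygen, and adds a hydrogen-bond donor, yet the half-life does not move beyond the scatter. Nothing in the data shown explains why this exchange leaves the number where it is.

On these data alone, only these two five-membered aromatic rings have been compared at this place, so it remains open whether a group of a different kind on the same carbon, such as a carboxylic acid or a dimethylamino group, would shift the half-life. As far as these compounds go, it is also open whether the same exchange would give a similar step on a compound with a different substitution pattern, since this single pair speaks only for its own shared core.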